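The source may report more compounds than this note shows. Statements on the series, on what has been measured and on what is new or still open speak of the compounds shown alone.

Values measured in a functional assay on MCF7 cells (Homo sapiens) for cytotoxicity, read by MTT assay, with a stated time of 72 h (a lower number here means a stronger inhibitor, a higher number a weaker inhibitor), are as follows
- compound 1 `COc1cccc(/C=C2\CCC/C(=C\c3ccccc3Cl)C2=O)c1OC` at 11300 nM
- compound 2 `COc1cccc(/C=C2\CCC/C(=C\c3ccc(Cl)cc3)C2=O)c1OC` at 10300 nM
- compound 3 `COc1cccc(/C=C2\CCC/C(=C\c3ccc(Br)cc3)C2=O)c1OC` at 13800 nM

Compound 3 at 13800 nM stands level with the other two, with a 1.2-fold higher number from compound 1 to compound 3 (0.09 log units; within the scatter) and a 1.3-fold higher number from compound 2 to compound 3 (0.13 log units; within the scatter) both within the scatter. Compound 4 `COc1cccc(/C=C2\CCC/C(=C\c3cccc(O)c3)C2=O)c1OC` differs by 3-hydroxyphenyl in place of 4-bromophenyl on a double-bonded chain carbon bound to a double-bonded ring carbon in that 3-hydroxyphenyl replaces 4-bromophenyl on a double-bonded chain carbon bound to a double-bonded ring carbon. Going by the values given here, the steps that bear on this only move or swap chloro and bromo, and a 1.1-fold lower number from compound 1 to compound 2 (0.04 log units; within the scatter) is likewise within the scatter. None of them tests a hydroxy group, so this is weak guidance, and no step beyond the scatter is expected in this assay here. The expected change is a 1.4-fold lower number from compound 3 to compound 4 (0.14 log units; within the scatter) as an estimate only. Compound 4 is expected at 10000 nM within an estimated range of 4000 nM to 25000 nM overall.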

Compound 4, half-maximal inhibitory concentration: 8800 nM
Compound 4: middle estimate off by 1.1-fold (0.06 log units), on the high side, within the range that was stated.
By their numbers in this assay, from the lowest: compounds 4, 2, 1 and 3 (each within the scatter of the next).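

In this assay, 3-hydroxyphenyl, the only group among these four that carries a hydrogen-bond donor on a double-bonded chain carbon bound to a double-bonded ring carbon, stands level with all three halogen-bearing groups: a 1.6-fold lower number from compound 3 to compound 4 (0.20 log units; within the scatter), a 1.2-fold lower number from compound 2 to compound 4 (0.07 log units; within the scatter) and a 1.3-fold lower number from compound 1 to compound 4 (0.11 log units; within the scatter). Here, then, the halogen-bearing groups give way to a hydroxy-bearing one with no step beyond the scatter. No measured evidence accounts for this result.

As far as these compounds go, whether 4-hydroxyphenyl, an amine or a carboxylic acid at this place would also stay level remains open. From the compounds shown here alone, the shared core is the same in all four compounds, so changes there remain open too.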